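This account rests on a few compounds, and the source may have more. Where it says the series, first, only, none or still open, it means among the compounds named here.

In a functional assay on MCF7 cells (Homo sapiens) for inhibition, read by sulforhodamine B assay (on this read-out higher numbers stand for weaker inhibition and lower numbers for stronger inhibition), compound 3 (`O=C1C=C(NC2CCCC2)C(=O)c2c1nc1n2[C@H]2OC[C@@H](O)[C@H]2OC1`) gives > 16000 nM, which is a limit and not a number. Compound 2 (`Cc1ccc(NC2=CC(=O)c3c(nc4n3[C@H]3OC[C@@H](O)[C@H]3OC4)C2=O)cc1`) gives > 4000 nM, which is also a limit. Going by the values given here, compound 1 (`CCc1ccc(NC2=CC(=O)c3c(nc4n3[C@H]3OC[C@@H](O)[C@H]3OC4)C2=O)cc1`) gives 8990 nM, the only actual number in the set.

Compound 4 (`Cc1ccc(NC2=CC(=O)c3nc4n(c3C2=O)[C@H]2OC[C@@H](O)[C@H]2OC4)cc1C`) differs from compound 3 as follows: 3,4-dimethylphenyl in place of cyclopentyl on an amine nitrogen. In short, 3,4-dimethylphenyl stands in place of cyclopentyl on an amine nitrogen. Among the compounds with values here, no measured step covers this change. Within the data shown here, the one step available, a step that the limit leaves unreadable from compound 1 to compound 2, has no readable size. Among the measured compounds shown here, the only guide is therefore compound 1 at 8990 nM, which also has an aromatic ring on the amine nitrogen, though the arrangement of its core differs from that of compound 3. A modest step toward stronger inhibition is expected, with wide uncertainty, and a further limit remains possible.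

The estimated step is an at least 2.2-fold lower number from compound 3 to compound 4 (0.35 log units; beyond the scatter). The expected value for compound 4 is 7000 nM, with an estimated range of 2500 nM to 20000 nM.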

Compound 4, half-maximal inhibitory concentration: 2080 nM
Beside the measured number, compound 4's estimate is 3.4-fold (0.53 log units) above it, outside the stated range (below it).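

In this assay, going by these compounds alone, the change from cyclopentyl to 3,4-dimethylphenyl on the amine nitrogen gives an at least 7.6-fold lower number from compound 3 to compound 4 (0.88 log units; beyond the scatter) and is the first step in this set with a readable size. From the compounds shown here alone, compound 3 at > 16000 nM is a limit, and the full size of the step stays unknown. On this core, (3,4-dimethylphenyl)amino gives an actual number where cyclopentylamino does not, so the group on this amine nitrogen clearly matters here.

The step from compound 1 to compound 2 cannot be read, and the core of those two differs from that of compound 3 and compound 4, so no single-place comparison links the two pairs. Going by these compounds, whether an unsubstituted phenyl, or a phenyl carrying a methoxy group or a carboxylic acid, on the same amine nitrogen holds this level on the core of compound 4 remains open.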